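Fluoro Gives Way to Phenoxy on the Shared Core

A few compounds are considered here, and "the series" means these few. Any claim that something is new, unique, unknown or untested is made for them only; others in the source may bear on it.

Going by the values given here, in a functional assay on KB-V1 cells (Homo sapiens) for cytotoxicity, read by MTT assay, with a stated time of 72 h (a lower number here means a stronger inhibitor, a higher number a weaker inhibitor), compound 2 `O=C1Nc2ccccc2/C1=N/NC(=S)Nc1ccc(F)cc1` gives 1920 nM, the only true number so far. Compound 1 `O=C1Nc2ccccc2/C1=N/NC(=S)Nc1cccnc1` gives > 50000 nM, which is a limit of the assay. Among the compounds with values here, the single measured step, an at least 26-fold lower number from compound 1 to compound 2 (1.41 log units; beyond the scatter), is large, but it swapped a different group, so it bears only loosely on what follows. Compound 3 `O=C1Nc2ccccc2/C1=N/NC(=S)Nc1ccc(Oc2ccccc2)cc1` differs from compound 2 by phenoxy in place of fluoro on an aromatic carbon. With so little to go on, only a modest step is expected, a 2.4-fold lower number from compound 2 to compound 3 (0.38 log units; beyond the scatter). Compound 3 is estimated at 800 nM, with a range of 200 nM to 3000 nM.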

Compound 3, half-maximal inhibitory concentration: 1670 nM
Compound 3: middle estimate off by 2.1-fold (0.32 log units), on the low side; the range from low to high includes it.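

Swapping fluoro for phenoxy on this aromatic carbon, para to a large group, gives a 1.1-fold lower number from compound 2 to compound 3 (0.06 log units; within the scatter) in this assay. The two compounds therefore read alike, so this position accepts the much larger phenoxy group, with its own aromatic ring, without a measurable loss in this cell assay. Nothing shown here explains why the two groups read alike. Still open, from the compounds shown here alone, is whether an amine, a carboxylic acid or a longer alkyl chain at this position would keep the same level.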